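Triazole thioethers: nitro to fluoro on the hydrazone aryl

The source may report more compounds than this note shows. Statements on the series, on what has been measured and on what is new or still open speak of the compounds shown alone.

The series shares one core, seen in compound 1 `Clc1ccc(CSc2nnc(-c3ccncc3)n2-c2ccccc2)cc1`, compound 2 `Fc1ccc(CSc2nnc(-c3ccncc3)n2-c2ccccc2)c(F)c1` and compound 3 `O=C(CSc1nnc(-c2ccncc2)n1-c1ccccc1)N/N=C/c1ccc([N+](=O)[O-])cc1`. In a functional assay on HepG2 cells (Homo sapiens) for inhibition, read by MTT assay, with a stated time of 48 h (on this read-out higher numbers stand for weaker inhibition and lower numbers for stronger inhibition), compound 1 gives 16900 nM, compound 2 gives 10200 nM and compound 3 gives 15900 nM. Going by the values given here, the only one-place step among the measured compounds is a 1.7-fold lower number from compound 1 to compound 2 (0.22 log units; within the scatter). Compound 3 lies among the other two numbers: its nearest neighbour is compound 1, and the gap to compound 2 is also within the scatter, so the three measured values are not separated in this assay.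

Compound 4 `O=C(CSc1nnc(-c2ccncc2)n1-c1ccccc1)N/N=C/c1ccc(F)cc1` differs from compound 3 by fluoro in place of nitro on an aromatic carbon. Among the compounds with values here, no measured step alters this part of the molecule; the one recorded step, a 1.7-fold lower number from compound 1 to compound 2 (0.22 log units; within the scatter), exchanges halogens on a different aryl group and stays within the scatter. Nothing in the data points to a change beyond the scatter from compound 3 to compound 4, and the spread of the whole series is small. The step of a 1.1-fold lower number from compound 3 to compound 4 (0.03 log units; within the scatter) is therefore expected to stay within the scatter, in no firm direction. For compound 4 the expected value in this assay is 15000 nM, with a range from 6000 nM to 40000 nM.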

Compound 4, half-maximal inhibitory concentration: 9330 nM
For compound 4 the middle estimate is 1.6-fold (0.21 log units) above the measured one; low and high end bracket the measured number.
By their numbers in this assay, from the lowest: compounds 4, 2, 3 and 1 (each within the scatter of the next).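

Going by these compounds alone, on the hydrazone aryl, the exchange of 4-nitrophenyl for 4-fluorophenyl gives a 1.7-fold lower number from compound 3 to compound 4 (0.23 log units; within the scatter) in this assay, and this is the first reading of any change at this position. Replacing nitro, with its 3 heavy atoms, by the single heavy atom of fluoro on an aromatic carbon, para to a large group, therefore does not separate the two compounds in this read-out, so this position accepts both groups without a difference that can be told from the scatter. Within the data shown here, no measurement on these compounds bears on the result beyond the values themselves.

Whether an amine or a carboxylic acid on the same aromatic carbon would move the number beyond the scatter remains open, since nitro and fluoro are the only groups shown there. As far as these compounds go, compound 3 and compound 4 also differ from compound 1 and compound 2 in more than one place, so the contribution of the hydrazone chain on the sulfur to the read-out remains open as well.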